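A Nitrile in Place of Chlorine, Near the Limit

A few compounds are considered here, and "the series" means these few. Any claim that something is new, unique, unknown or untested is made for them only; others in the source may bear on it.

Compound 1, `CCS(=O)(=O)Nc1ccc(NC(=O)c2ccc(C#N)cc2)cc1OC`, gives 66400 nM in an ADME assay on RAW264.7 cells (Mus musculus) for cytotoxicity, read by MTT assay, with a stated time of 48 h; a higher number here means a weaker inhibitor, a lower number a stronger inhibitor.
Compound 2, `CS(=O)(=O)Nc1ccc(NC(=O)c2ccc(C#N)cc2)cc1Cl`, gives only a limit of the assay in this assay: > 250000 nM.
Compound 3, `CCS(=O)(=O)Nc1ccc(NC(=O)c2ccc(Cl)cc2)cc1Cl`, likewise gives only a limit in this assay: > 250000 nM.

Compound 3 therefore has no number of its own here, only a limit, and it shares that position with one other compound, as the limit of > 250000 nM in this assay, at which 2 of the 3 values shown sit, shows. Among the three measured compounds, only compound 1 yields an actual number, and that number is weak.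

Compound 4, `CCS(=O)(=O)Nc1ccc(NC(=O)c2ccc(C#N)cc2)cc1Cl`, has not yet been measured in this assay. It differs from compound 3 in one place: cyano in place of chloro on an aromatic carbon. The amide, the sulfonamide and the chloro group on the other ring stay as they are.

Going by the values given here, with no measured step to rest on, the expectation can only lean on where the measured compounds stand, and two of them sit at the limit. The step from compound 3 to compound 4 is expected to be small or absent, an at least 1.2-fold lower number from compound 3 to compound 4 (0.09 log units; that floor lies within the scatter), with a real chance that compound 4 again reports only a limit. Compound 4 is estimated at 200000 nM, within a range from 60000 nM to 400000 nM.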

Compound 4, half-maximal inhibitory concentration: 226000 nM
Compound 4: middle estimate off by 1.1-fold (0.05 log units), on the low side; low and high end bracket the measured number.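

Compound 4 gives the 4-cyanophenyl series a measured number to set against compound 3, which reports only a limit of the assay, so the change from 4-chlorophenyl to 4-cyanophenyl can be read only as a floor: an at least 1.1-fold lower number from compound 3 to compound 4 (0.04 log units; that floor lies within the scatter). The methyl in place of hydrogen on the chain carbon bound to the sulfonyl sulfur can likewise be read only as a floor, since compound 2 also reports only a limit: an at least 1.1-fold lower number from compound 2 to compound 4 (0.04 log units; that floor lies within the scatter). The firm comparison in this assay is the one with chloro in place of methoxy on an aromatic carbon, which gives a 3.4-fold higher number from compound 1 to compound 4 (0.53 log units; beyond the scatter).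

As far as these compounds go, how far the nitrile truly moves the value at this position stays open, as compound 3 has no number of its own: the limit of > 250000 nM in this assay, at which 2 of the 4 values shown sit. Also open is whether an amine or a carboxylic acid on this ring, or a longer chain on the sulfonyl group, would give a number in this assay rather than another limit.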